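A few compounds are considered here, and "the series" means these few. Any claim that something is new, unique, unknown or untested is made for them only; others in the source may bear on it.

Measured compounds:

Compound 1 `CCc1cccc(C)c1-n1nncc1CN1C(=O)C2(C(C#N)=C(N)Oc3c(N)cc4nc5ccccc5nc4c32)c2ccccc21` in a functional assay on A549 cells (Homo sapiens) for antiproliferative activity, read by MTT assay, with a stated time of 48 h (on this read-out lower numbers stand for stronger inhibition and higher numbers for weaker inhibition), gives > 50000 nM, which is a limit of the assay.
Compound 2 `Cc1cc(C)cc(-n2nncc2CN2C(=O)C3(C(C#N)=C(N)Oc4c(N)cc5nc6ccccc6nc5c43)c3ccccc32)c1` in this assay gives 31200 nM.
Compound 3 `N#CC1=C(N)Oc2c(N)cc3nc4ccccc4nc3c2C12C(=O)N(Cc1cnnn1-c1ccc(Cl)cc1[N+](=O)[O-])c1ccccc12` in this assay gives > 50000 nM, a limit and not a number.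

Compound 3 thus stands at the limit, where (the limit of > 50000 nM in this assay, at which 2 of the 3 values shown sit). The step of interest is 2,4,6-trimethylphenyl in place of 4-chloro-2-nitrophenyl on an aromatic nitrogen, giving compound 4 `Cc1cc(C)c(-n2nncc2CN2C(=O)C3(C(C#N)=C(N)Oc4c(N)cc5nc6ccccc6nc5c43)c3ccccc32)c(C)c1`. The measured steps that bear on it are an at least 1.6-fold higher number from compound 2 to compound 3 (0.20 log units; that floor lies within the scatter) and a step that the two limits leave unreadable from compound 1 to compound 3; the first is only a floor within the scatter, the second cannot be read. The related change an at least 1.6-fold lower number from compound 1 to compound 2 (0.20 log units; that floor lies within the scatter), also a floor within the scatter, is the only hint that methyl-substituted phenyl groups give a readable number in this series. Compound 4 carries three methyls and, like compound 1, is substituted on both sides of the attachment; the change is therefore expected to yield an at least 1.1-fold lower number from compound 3 to compound 4 (0.04 log units; that floor lies within the scatter), that is nothing beyond the scatter. Compound 4 is estimated at 45000 nM, range 20000 nM to 100000 nM, with a good chance that only a limit is reported.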

Compound 4, half-maximal inhibitory concentration: 12700 nM
The estimate for compound 4 lay 3.5-fold (0.55 log units) above the measured number, and the stated range ends above it.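

In this assay, the series now has a step between two actual numbers, which shows that the choice of methyl-substituted phenyl on the aromatic nitrogen matters at this position: a 2.5-fold lower number from compound 2 to compound 4 (0.39 log units; beyond the scatter). Against the two compounds at the limit, 2,4,6-trimethylphenyl gives an at least 3.9-fold lower number from compound 3 to compound 4 (0.59 log units; beyond the scatter) and an at least 3.9-fold lower number from compound 1 to compound 4 (0.59 log units; beyond the scatter), and both are floors: the limit of > 50000 nM in this assay, at which 2 of the 4 values shown sit. Alkyl groups on the phenyl do not by themselves secure a readable number: compound 1 gives > 50000 nM, a limit of the assay.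

Compound 3 and compound 4 differ in the chloro and nitro groups as well as the methyls, so the compounds shown do not tell which of these carries the step. On these data alone, whether a methoxy or an amine on this phenyl would shift the number further remains open.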